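A nitrile enters a series with little spread

The compounds below may be only part of what the source reports. "The series", "measured", "known", "first", "only" and "open" are said of these compounds alone.

Of the compounds shown here, three with a shared core have been measured in a functional assay on DU-145 cells (Homo sapiens) for antiproliferative activity, read by propidium iodide staining, with a stated time of 96 h; on this read-out lower numbers stand for stronger inhibition and higher numbers for weaker inhibition. Compound 1 `CC(O)(COc1cccc(S(F)(F)(F)(F)F)c1)C(=O)Nc1ccc(S(F)(F)(F)(F)F)cc1` gives 29600 nM, compound 2 `CC(O)(COc1cccc(C(F)(F)F)c1)C(=O)Nc1ccc(S(F)(F)(F)(F)F)cc1` gives 21900 nM, and compound 3 `CC(O)(COc1cccc(OC(F)(F)F)c1)C(=O)Nc1ccc(S(F)(F)(F)(F)F)cc1` gives 18400 nM. Compound 2 therefore stands with the other two, all within the usual scatter of one another.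

Compound 4 `CC(O)(COc1ccc(C#N)c(F)c1)C(=O)Nc1ccc(S(F)(F)(F)(F)F)cc1` differs from compound 2 by 4-cyano-3-fluorophenyl in place of 3-(trifluoromethyl)phenyl on an oxygen on a saturated carbon.

Among the compounds with values here, the steps that bear on this change are swaps of a single group on an aromatic carbon: a 1.4-fold lower number from compound 1 to compound 2 (0.13 log units; within the scatter), a 1.6-fold lower number from compound 1 to compound 3 (0.21 log units; within the scatter) and a 1.2-fold lower number from compound 2 to compound 3 (0.08 log units; within the scatter). All three are small, but none of them involves a nitrile, so they are only a partial guide and the range must stay wide. The expected change is no more than scatter, with no favoured direction: a 1.1-fold lower number from compound 2 to compound 4 (0.04 log units; within the scatter). For compound 4 the estimated value is 20000 nM, with an expected range from 8000 nM to 50000 nM.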

Compound 4, half-maximal inhibitory concentration: 30400 nM
For compound 4 the middle estimate is 1.5-fold (0.18 log units) below the measured one; low and high end bracket the measured number.
By their numbers in this assay, from the lowest: compounds 3, 2, 1 and 4 (each within the scatter of the next).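

In this assay, exchanging 3-(trifluoromethyl)phenyl for 4-cyano-3-fluorophenyl on the oxygen gives a 1.4-fold higher number from compound 2 to compound 4 (0.14 log units; within the scatter). Within the data shown here, this position has therefore now tolerated a change to the substituents of the whole ring, bringing in a nitrile and a hydrogen-bond acceptor, and not only the swap of a single group seen among the earlier compounds, with the number still staying within the scatter. Nothing available explains why the read-out barely responds to this larger change.

As far as these compounds go, whether that insensitivity would hold for quite different groups on this ring, such as an amine or a carboxylic acid, remains open. All the compounds shown also keep the rest of the shared core unchanged, so the effect of a longer chain in that part is unknown too.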